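Swapping Chloro for Methyl in a Cell Tolerance Test

The compounds below may be only part of what the source reports. "The series", "measured", "known", "first", "only" and "open" are said of these compounds alone.

Measured in an ADME assay on NIH3T3 cells (Mus musculus) for cytotoxicity, read by MTT assay, with a stated time of 48 h; a lower number here means that less compound is tolerated, a higher number that more compound is tolerated:
- compound 1 `COc1ccc(C(=O)/C=C/c2ccc(C)cc2)cc1S(N)(=O)=O`: 4300 nM
- compound 2 `COc1ccc(C(=O)/C=C/c2ccc(Cl)cc2)cc1S(=O)(=O)Nc1c(N)nc(SC)[nH]c1=O`: 13000 nM

Compound 2, at 13000 nM, has the higher of the two numbers, so the cells tolerate more of it than of compound 1, at 4300 nM. That gap lies beyond the usual scatter. However, these two compounds differ in more than one place, so the gap does not isolate any single change.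

The next compound to be tested is compound 3 `COc1ccc(C(=O)/C=C/c2ccc(C)cc2)cc1S(=O)(=O)Nc1c(N)nc(SC)[nH]c1=O`. It is compound 2 with one change: methyl in place of chloro on an aromatic carbon. In short, this puts methyl in place of chloro on an aromatic carbon, turning 4-chlorophenyl into 4-methylphenyl. For the measured compounds named here, no measured pair shows this swap alone, so the expectation in this assay is only tentative. Compound 1 also carries 4-methylphenyl and sits at 4300 nM, which suggests a slight downward lean. The expected change, a 1.2-fold lower number from compound 2 to compound 3 (0.07 log units; within the scatter), is small and within the scatter. Compound 3 is estimated at 11000 nM, with an expected range of 5000 nM to 25000 nM.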

Compound 3, concentration lethal to 50% of the cells: 7200 nM
Compound 3: the middle estimate sits 1.5-fold (0.18 log units) above what was measured; measured number inside the range.
By their numbers in this assay, from the lowest: compounds 1, 3 and 2 (each within the scatter of the next, the first and the last beyond it).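

In this assay, the swap of chloro for methyl on this aromatic carbon, para to a large group, can now be read on its own: it gives a 1.8-fold lower number from compound 2 to compound 3 (0.26 log units; within the scatter), which is within the usual scatter, so 4-chlorophenyl and 4-methylphenyl cannot be told apart in this test. The new compound also isolates the large ring-bearing group on the sulfonamide nitrogen, which stands in place of a hydrogen atom and gives a 1.7-fold higher number from compound 1 to compound 3 (0.22 log units; within the scatter), again within the scatter, so neither single change on its own moves the number beyond what repeat measurements would show. Nothing measured here speaks to the cause of these numbers.

The compounds shown leave open whether other groups at the same ring position, such as a methoxy group, an amine or a carboxylic acid, would also stay within the scatter of compound 3. They also leave open whether a different group on the sulfonamide nitrogen, such as a simple acetyl group or a plain phenyl ring, would give a step large enough to read.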